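Swapping tert-butyl for sec-butyl on compound 2

A few compounds are considered here, and "the series" means these few. Any claim that something is new, unique, unknown or untested is made for them only; others in the source may bear on it.

- Compound 1 `CCC/N=c1\c(O)c(O)\c1=N/c1cccnc1` gives > 30000 nM as a limit
- Compound 2 `CC(C)(C)/N=c1\c(O)c(O)\c1=N/c1ccc(C#N)cc1` gives 560 nM as a measured number

Going by the values given here, in a functional assay for inhibition, with Rattus norvegicus as the target (a lower number here means a stronger inhibitor, a higher number a weaker inhibitor), compound 2 gives 560 nM as the only true number so far. Compound 1 gives > 30000 nM as its result, and this is a limit and not a number.

Compound 3 `CCC(C)/N=c1\c(O)c(O)\c1=N/c1ccc(C#N)cc1` has the same atoms as compound 2, joined differently: it carries sec-butyl in place of tert-butyl on a double-bonded nitrogen in the same shared core. Among the compounds with values here, no measured pair of compounds differing in one place is available as a guide, so this expectation is only a cautious one. A modest move towards weaker inhibition is expected in this assay, not a collapse to the limit. The expected change is a 1.8-fold higher number from compound 2 to compound 3 (0.25 log units; within the scatter) in size. For compound 3 the estimated value is 1000 nM within an expected range from 250 nM to 4000 nM in this assay.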

Compound 3, half-maximal inhibitory concentration: 2100 nM
The estimate for compound 3 lay 2.1-fold (0.32 log units) below the measured number, within the range that was stated.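

In this assay, exchanging tert-butyl for sec-butyl on the double-bonded nitrogen gives a 3.8-fold higher number from compound 2 to compound 3 (0.57 log units; beyond the scatter), so compound 3 is the weaker inhibitor of the pair. This is the only comparison shown that changes a single place, and it shows that this position responds to how the same atoms are joined, not only to which atoms the group contains. Nothing measured here bears on why the arrangement of the chain matters.

The compounds shown leave open how a straight butyl chain, a cyclobutyl ring or a chain ending in an amine would behave at this position on the shared core. They also leave open whether the same swap would have an effect of similar size in compounds carrying a carboxylic acid in place of the nitrile.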